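Adding a chloro group to compound 2: an expected step

A few compounds are considered here, and "the series" means these few. Any claim that something is new, unique, unknown or untested is made for them only; others in the source may bear on it.

Measured so far:
compound 1 `N#CC1=C(N)Oc2c(c3nc4ccccc4nc3c3ccccc23)C12C(=O)N(Cc1cnnn1-c1ccc(F)c(Cl)c1)c1ccccc12` — > 50000 nM
compound 2 `N#CC1=C(N)Oc2c(N)cc3nc4ccccc4nc3c2C12C(=O)N(Cc1cnnn1-c1ccc(F)cc1)c1ccccc12` — > 50000 nM

Compound 1 `N#CC1=C(N)Oc2c(c3nc4ccccc4nc3c3ccccc23)C12C(=O)N(Cc1cnnn1-c1ccc(F)c(Cl)c1)c1ccccc12` carries a 3-chloro-4-fluorophenyl group on its triazole and the shared core without the aromatic amine. In a functional assay on A549 cells (Homo sapiens) for antiproliferative activity, read by MTT assay, with a stated time of 48 h (on this read-out lower numbers stand for stronger inhibition and higher numbers for weaker inhibition), compound 1 gives > 50000 nM, which is a limit of the assay and not a number. Compound 2 `N#CC1=C(N)Oc2c(N)cc3nc4ccccc4nc3c2C12C(=O)N(Cc1cnnn1-c1ccc(F)cc1)c1ccccc12` carries the aromatic amine on the core and a 4-fluorophenyl group. In this assay compound 2 gives > 50000 nM, again a limit and not a number. Within the data shown here, both values sit at the limit of > 50000 nM in this assay, at which 2 of the 2 values shown sit, so no step between them can be sized.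

Compound 3 `N#CC1=C(N)Oc2c(N)cc3nc4ccccc4nc3c2C12C(=O)N(Cc1cnnn1-c1ccc(F)c(Cl)c1)c1ccccc12` is not yet measured. It differs from compound 2 by chloro in place of hydrogen on an aromatic carbon. Compound 1, which already carries the 3-chloro-4-fluorophenyl group, gives only a limit, as does compound 2. No step beyond the scatter is therefore expected in this assay, and the estimated step is a step that the limit leaves unreadable from compound 2 to compound 3. Compound 3 is expected to give about 60000 nM, within the range 25000 nM to 150000 nM, most likely as a limit again.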

Compound 3, half-maximal inhibitory concentration: 43400 nM
Compound 3: middle estimate off by 1.4-fold (0.14 log units), on the high side; low and high end bracket the measured number.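

Compound 3 is the only compound shown that gives a number and not a limit in this assay, so the 3-chloro-4-fluorophenyl group, paired with the aromatic amine on the shared core, now has a place on the scale. Chloro in place of hydrogen, ortho to the fluoro group, gives an at least 1.1-fold lower number from compound 2 to compound 3 (0.06 log units; that floor lies within the scatter) and so shows no change beyond the scatter at this position, though it does not rule one out. The true size of the step stays unread because one of its ends is a limit: the limit of > 50000 nM in this assay, at which 2 of the 3 values shown sit.

The compounds shown leave open whether bromo, methyl or trifluoromethyl in place of this chloro would move the number further in this assay, and whether chloro would do the same with hydrogen in place of the fluoro group. Also open, from the compounds shown here alone, is whether a hydroxy group or an acetamide in place of the aromatic amine on the core would keep a readable number alongside the 3-chloro-4-fluorophenyl group.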